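This account rests on a few compounds, and the source may have more. Where it says the series, first, only, none or still open, it means among the compounds named here.

Compound 1 `O=c1nc(N2CCN(NCc3ccc(C(F)(F)F)cc3)CC2)sc2c([N+](=O)[O-])cc(C(F)(F)F)cc12` was examined in an ADME assay on Vero cells (Chlorocebus sabaeus) for cytotoxicity, read by MTT assay, with a stated time of 72 h; a lower number here means that less compound is tolerated, a higher number that more compound is tolerated. In this assay compound 1 gives > 64 ug/mL, which is a limit of the assay rather than a number. Compound 2 `CC(NN1CCN(c2nc(=O)c3cc(C(F)(F)F)cc([N+](=O)[O-])c3s2)CC1)c1ccc(OC(F)(F)F)cc1` was examined in the same way. In this assay compound 2 gives > 64 ug/mL, again a limit and not a number. Compound 1 therefore stands at the limit of > 64 ug/mL in this assay, at which 2 of the 2 values shown sit, and nothing further can be said of its place among the measured compounds. Compound 3 `O=c1nc(N2CCN(Nc3ccc(C(F)(F)F)cc3)CC2)sc2c([N+](=O)[O-])cc(C(F)(F)F)cc12` has not yet been measured in this assay. It differs from compound 1 in one place: 4-(trifluoromethyl)phenyl in place of 4-(trifluoromethyl)benzyl on an amine nitrogen. For the measured compounds named here, no step between two measured compounds is available to calibrate this change. Because both measured values sit at the limit of > 64 ug/mL in this assay, at which 2 of the 2 values shown sit, the expected step is a number no higher from compound 1 to compound 3 (the limit leaves the size open), none beyond the scatter. Compound 3 is expected to give about 64 ug/mL, within 32 ug/mL to 128 ug/mL, most probably again reported only as a limit.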

Compound 3, half-maximal cytotoxic concentration: > 64 ug/mL
Compound 3 gave a limit, no number (the forecaster's own chance of this, stated with the estimate: 75%); the middle value sits exactly at the limit.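

For the compounds shown here, no step from compound 1 to compound 3 can be read, since both stand only as limits: the limit of > 64 ug/mL in this assay, at which 3 of the 3 values shown sit. The compounds shown leave open where the true values lie in this assay, and whether 4-(trifluoromethyl)phenyl in place of 4-(trifluoromethyl)benzyl changes the value at all.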